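Carboxyalkyl amides of a polyhydroxy cyclohexane carboxamide core

The compounds below may be only part of what the source reports. "The series", "measured", "known", "first", "only" and "open" are said of these compounds alone.

Measured so far:
compound 1, `O=C(O)CNC(=O)[C@]1(O)C[C@@H](O)[C@@H](O)[C@H](O)C1`: > 50000000 nM
compound 2, `O=C(O)CCCNC(=O)[C@]1(O)C[C@@H](O)[C@@H](O)[C@H](O)C1`: > 50000000 nM

Compound 1 `O=C(O)CNC(=O)[C@]1(O)C[C@@H](O)[C@@H](O)[C@H](O)C1` carries a carboxymethyl group on the amide nitrogen of the shared core. In an assay on HL-60 cells for inhibition of E-selectin (Homo sapiens) (a higher number here means a weaker inhibitor, a lower number a stronger inhibitor), compound 1 reaches only a limit of the assay, > 50000000 nM. Compound 2 `O=C(O)CCCNC(=O)[C@]1(O)C[C@@H](O)[C@@H](O)[C@H](O)C1` bears a 3-carboxypropyl chain instead. In this assay compound 2 likewise reaches only a limit, > 50000000 nM. The step from compound 1 to compound 2, a step that the two limits leave unreadable from compound 1 to compound 2, cannot be read because both values are limits (the limit of > 50000000 nM in this assay, at which 2 of the 2 values shown sit). Within the data shown here, compound 2 therefore stands at the limit, level with the only other measured compound.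

Compound 3 `O=C(O)CC[C@H](NC(=O)[C@]1(O)C[C@@H](O)[C@@H](O)[C@H](O)C1)C(=O)O` is the next member. It differs from compound 2 by carboxy in place of hydrogen on a saturated chain carbon bound to an amide-type nitrogen and a saturated chain carbon. Among the measured compounds shown here, no measured step bears on this change in a readable way: the single step available, from compound 1 to compound 2, is unreadable (the limit of > 50000000 nM in this assay, at which 2 of the 2 values shown sit). Against two limits, no direction can be set, and the change is expected to give at most a step that the limit leaves unreadable from compound 2 to compound 3 in this assay. Compound 3 is therefore estimated at 100000000 nM, with a range from 20000000 nM to 500000000 nM, most likely reported again as a limit.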

Compound 3, half-maximal inhibitory concentration: > 50000000 nM
Compound 3 was reported as a limit (the forecaster's own chance of this, stated with the estimate: 90%); the middle value lies beyond the limit too.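

Among these compounds, no step among compound 1, compound 2 and compound 3 can be read in this assay, because all three values are limits: the limit of > 50000000 nM in this assay, at which 3 of the 3 values shown sit. The compounds shown leave open whether any carboxyalkyl amide on the shared core gives a measurable value in this assay, and what the longer chain or the added carboxy changes there.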